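Compound 3 and its 4-methyl-2-nitrophenyl analogue

This account rests on a few compounds, and the source may have more. Where it says the series, first, only, none or still open, it means among the compounds named here.

In an ADME assay on MT4 cells (Homo sapiens) for cytotoxicity, read by MTT assay (on this read-out higher numbers stand for lower toxicity in this test and lower numbers for higher toxicity in this test), compound 1 (`Cc1ccc(NC(=O)CSc2nncnc2-c2cccc3ccccc23)c(Br)c1`) gives 166000 nM, compound 2 (`O=C(CSc1nncnc1-c1cccc2ccccc12)Nc1ccc(Cl)cc1Cl`) gives 254000 nM and compound 3 (`O=C(CSc1nncnc1-c1cccc2ccccc12)Nc1ccccc1Cl`) gives 63000 nM, the lowest of the three numbers. Compound 4 (`Cc1ccc(NC(=O)CSc2nncnc2-c2cccc3ccccc23)c([N+](=O)[O-])c1`) carries 4-methyl-2-nitrophenyl in place of 2-chlorophenyl on an amide-type nitrogen. Within the data shown here, two measured steps bear on this change: a 2.6-fold lower number from compound 1 to compound 3 (0.42 log units; beyond the scatter) and a 4.0-fold lower number from compound 2 to compound 3 (0.61 log units; beyond the scatter). Both are modest, and both end at the lower number. Neither involves a nitrophenyl group, so the evidence is indirect. The expected change in this assay is a modest estimated rise, a 2.2-fold higher number from compound 3 to compound 4 (0.35 log units; beyond the scatter). For compound 4 the estimated value is 140000 nM, with an expected range from 50000 nM to 350000 nM.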

Compound 4, half-maximal cytotoxic concentration: 147000 nM
For compound 4 the middle estimate is 1.1-fold (0.02 log units) below the measured one; measured number inside the range.
By their numbers in this assay, from the lowest: compound 3; then compounds 4, 1 and 2 (each within the scatter of the next).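

In this assay, 4-methyl-2-nitrophenyl on the amide-type nitrogen separates from 2-chlorophenyl (a 2.3-fold higher number from compound 3 to compound 4 (0.37 log units; beyond the scatter)). Nitro in place of bromo gives (a 1.1-fold lower number from compound 1 to compound 4 (0.05 log units; within the scatter)), and replacing 2,4-dichlorophenyl gives (a 1.7-fold lower number from compound 2 to compound 4 (0.24 log units; within the scatter)); both steps lie within the scatter, so compound 4 cannot be told apart from compound 1 or compound 2 in this test. Nothing available explains why these groups give these numbers. On these data alone, whether an amine or a carboxylic acid on this aromatic ring, or a longer chain in its place, would change the number remains open.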